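The source may hold more compounds than are shown below. What is called first, only, known or untested is meant among the compounds shown, and "the series" means these compounds.

Values so far in a functional assay on HL-60 cells (Homo sapiens) for cytotoxicity, read by WST assay, with a stated time of 48 h; on this read-out higher numbers stand for an effect only at larger amounts of compound and lower numbers for an effect already at smaller amounts
- compound 1 `O=C1OC[C@H](Cc2ccccc2)[C@H]1Cc1ccc(C(F)(F)F)cc1` gives 22000 nM
- compound 2 `CCCCOc1ccc(/C=C2\C(=O)OC[C@@H]2Cc2ccccc2)cc1` gives 58000 nM
- compound 3 `Cc1cccc(C[C@H]2COC(=O)[C@@H]2Cc2ccc(Cl)c(Cl)c2)c1` gives 22000 nM

Compound 3 stands level with compound 1, the two sharing the lowest of the three numbers. Compound 2 lies higher, beyond the scatter. Compound 4 `O=C1OC[C@H](Cc2ccc(F)c(F)c2)[C@H]1Cc1ccc(Cl)c(Cl)c1` is the next to be read, and it differs from compound 3 by 3,4-difluorophenyl in place of 3-methylphenyl on a saturated chain carbon bound to a saturated ring carbon, with 3,4-difluorophenyl in place of 3-methylphenyl on a saturated chain carbon bound to a saturated ring carbon.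

Going by the values given here, no two measured compounds differ in one place only, so the series offers no direct measure of such a change. Compound 1 and compound 3 differ in more than one place, yet their numbers are level, and this supports expecting a small effect here. A step within the scatter is expected in this assay, with no firm direction. The estimated change is a 1.1-fold higher number from compound 3 to compound 4 (0.06 log units; within the scatter), which stays within that scatter. For compound 4 the expected value is 25000 nM, with an estimated range from 11000 nM to 60000 nM.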

Compound 4, half-maximal effective concentration: 25000 nM
Compound 4: middle estimate and measured number agree at the digits printed; low and high end bracket the measured number.
By their numbers in this assay, from the lowest: compounds 1, 3 and 4 (each within the scatter of the next); then compound 2.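

In this assay the series now has its first comparison in one place: 3,4-difluorophenyl in place of 3-methylphenyl on a saturated chain carbon bound to a saturated ring carbon gives a 1.1-fold higher number from compound 3 to compound 4 (0.06 log units; within the scatter) and so stays within the scatter. At this position, one substituted phenyl ring can therefore replace the other with no readable change in this assay while the rest of the molecule stays fixed. No available measurement accounts for the size of this step.

From the compounds shown here alone, both groups in this step are substituted phenyl rings, so it remains open how the read-out responds at this position to a group of another kind, such as an amine, a carboxylic acid or a longer chain. Going by these compounds, it is also open whether this step keeps its size when the group elsewhere on the shared core changes.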